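A ring swap from compound 2 to compound 4

This account rests on a few compounds, and the source may have more. Where it says the series, first, only, none or still open, it means among the compounds named here.

Values in a physicochemical assay for lipophilicity, measured as octanol-water partition, at pH 7.4; on this read-out higher numbers stand for higher lipophilicity and lower numbers for lower lipophilicity:
- compound 1 `Cc1ccc(Cn2c(=O)[nH]c3c(N)nc(C(F)(F)F)cc32)nn1`: 1.1
- compound 2 `Cc1cccc(Cn2c(=O)[nH]c3c(N)nc(C(F)(F)F)cc32)n1`: 2.3
- compound 3 `Nc1nc(C(F)(F)F)cc2c1[nH]c(=O)n2Cc1ccc(C(F)(F)F)nc1`: "not determined" (no result reported)

Compound 2 holds the higher of the two numbers available, at 2.3. Compound 3 gave no number, so it offers no guide.

The next compound, compound 4 `COc1ccc(Cn2c(=O)[nH]c3c(N)nc(C(F)(F)F)cc32)cn1`, keeps the shared core. In it, 6-methoxypyridin-3-yl stands in place of 6-methylpyridin-2-yl on a saturated chain carbon bound to an aromatic nitrogen: 6-methoxypyridin-3-yl in place of 6-methylpyridin-2-yl on a saturated chain carbon bound to an aromatic nitrogen.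

Among the measured compounds shown here, only one measured step bears on this change, a swap at the same place, and it was large: a number 1.20 log units higher from compound 1 to compound 2 (beyond the scatter). So a ring exchange here can move the number a long way. That step is a single example, however, and it involved a different ring. In the present change, both the leaving and the entering ring have 1 hetero atom. No step beyond the scatter is therefore expected in this assay, and the estimated change is a number 0.10 log units higher from compound 2 to compound 4 (within the scatter). The estimated value for compound 4 is 2.4, with an expected range from 1.9 to 2.9.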

Compound 4, distribution coefficient: 2.8
Compound 4: middle estimate off by 0.40 log units, on the low side, and the stated range covers the measured number.
By their numbers in this assay, from the lowest: compound 1; then compound 2; then compound 4.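

In this assay, this place on a saturated chain carbon bound to an aromatic nitrogen gives a step beyond the scatter even when the leaving and the entering ring each have 1 hetero atom: a number 0.50 log units higher from compound 2 to compound 4 (beyond the scatter). Among the compounds shown here, with the shared core unchanged, the ring exchange also gives the widest gap among the numbers so far, a number 1.70 log units higher from compound 1 to compound 4 (beyond the scatter). Nothing available gives a measured reason for either step.

Going by these compounds, the swap from compound 2 to compound 4 alters both the ring's point of attachment and its group, with 6-methoxypyridin-3-yl replacing 6-methylpyridin-2-yl, so the share of each change in the step stays open. Also open, on these data alone, is where this assay would place a ring carrying an amine or a carboxylic acid in this same place.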